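From 4-(methylsulfanyl)phenyl to thiophen-2-yl on a shared core

The compounds below may be only part of what the source reports. "The series", "measured", "known", "first", "only" and "open" are said of these compounds alone.

Of the compounds shown here, three built on one shared core have been tested in a functional assay on DU-145 cells (Homo sapiens) for inhibition, read by MTT assay, with a stated time of 48 h; on this read-out higher numbers stand for weaker inhibition and lower numbers for stronger inhibition. Compound 1 `CCc1ccc(-c2nc3ccccn3c2Sc2ccccc2)cc1` gives 84500 nM. Compound 2 `C(=C/c1nc2ccccn2c1Sc1ccccc1)\c1ccccc1` gives 22000 nM. Compound 3 `CSc1ccc(-c2nc3ccccn3c2Sc2ccccc2)cc1` gives 52100 nM. To place compound 3 among these numbers, its nearest neighbour lies at a 1.6-fold lower number from compound 1 to compound 3 (0.21 log units; within the scatter), and its furthest at a 2.4-fold higher number from compound 2 to compound 3 (0.37 log units; beyond the scatter).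

The next compound is compound 4 `c1ccc(Sc2c(-c3cccs3)nc3ccccn23)cc1`, in which thiophen-2-yl takes the place of 4-(methylsulfanyl)phenyl on an aromatic carbon: thiophen-2-yl in place of 4-(methylsulfanyl)phenyl on an aromatic carbon. For the measured compounds named here, no measured compound carries thiophen-2-yl, so nothing shows this swap directly. Going by the values given here, the only guide is how far the number has moved when the group on this same carbon changed. The largest such move is modest, at a 3.8-fold lower number from compound 1 to compound 2 (0.58 log units; beyond the scatter), and the swap of ethyl for methylsulfanyl stays small, at a 1.6-fold lower number from compound 1 to compound 3 (0.21 log units; within the scatter). With so few compounds, neither direction is well supported, so no change beyond the scatter is expected in this assay. The expected step is a 1.2-fold lower number from compound 3 to compound 4 (0.09 log units; within the scatter). For compound 4 the estimated value is 42000 nM, with an expected range from 16000 nM to 100000 nM.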

Compound 4, half-maximal inhibitory concentration: 24100 nM
For compound 4 the middle estimate is 1.7-fold (0.24 log units) above the measured one; the range from low to high includes it.
By their numbers in this assay, from the lowest: compounds 2 and 4 (each within the scatter of the next); then compounds 3 and 1 (each within the scatter of the next).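

In this assay, thiophen-2-yl on this aromatic carbon gives the first change away from a 4-substituted phenyl group to a smaller ring, with 5 heavy atoms in place of 8, and the step is a 2.2-fold lower number from compound 3 to compound 4 (0.33 log units; beyond the scatter) and, measured against the ethyl-bearing compound, a 3.5-fold lower number from compound 1 to compound 4 (0.54 log units; beyond the scatter) as well. Set against the 2-phenylethenyl group, the same ring gives a 1.1-fold higher number from compound 2 to compound 4 (0.04 log units; within the scatter) so these two quite different groups cannot be told apart here, and among the four compounds both sit at lower numbers than the two carrying 4-ethylphenyl and 4-(methylsulfanyl)phenyl, with no compound going against this split. Nothing measured here explains why the number moves with these groups.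

The compounds shown leave open whether the lower numbers belong to thiophen-2-yl and 2-phenylethenyl in particular, or would also come with a plain phenyl ring, a furan-2-yl ring or a phenyl ring bearing an amine on this carbon. The phenylsulfanyl group is the same in all four compounds, and how the number would respond to a carboxylic acid or a longer chain in its place remains an open question.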